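The compounds below may be only part of what the source reports. "The series", "measured", "known", "first", "only" and "open" are said of these compounds alone.

Working notes on a small series of pyridyl amidrazone thiosemicarbazides. Compound 1 `N/C(=N\NC(=S)N1CCOCC1)c1ccccn1` gives 26.8% in a functional assay on A-375 cells (Homo sapiens) for cytotoxicity, read by MTT assay, with a stated time of 72 h, tested at 1 uM; on this read-out lower numbers stand for less inhibition of growth and higher numbers for more inhibition of growth at the one concentration tested. Compound 2 `Cc1cccc(/C(N)=N/NC(=S)N2CCSCC2)n1` gives 47.2% in this assay, the higher of the two numbers, with a gap to compound 1 that lies beyond the scatter. Within the data shown here, compound 1 and compound 2 differ in two places at once, so their two values give no single step. Compound 3 `Cc1cccc(/C(N)=N/NC(=S)N2CCOCC2)n1` is not yet measured in this assay; it carries morpholin-4-yl in place of thiomorpholin-4-yl on a thiocarbonyl carbon. Among the measured compounds shown here, no measured pair shows this change on its own. Compound 3 shares the morpholin-4-yl with compound 1, whose read-out 26.8% is the lower of the two measured numbers. A downward step of a size beyond the scatter is therefore expected, a number 13.2 percentage points lower from compound 2 to compound 3 (beyond the scatter). Compound 3 is expected to give 34% in this assay, within a range from 20% to 50%.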

Compound 3, percent growth inhibition at one concentration: 30.2%
For compound 3 the middle estimate is 3.8 percentage points above the measured one; the measured number falls inside the stated range.
By their numbers in this assay, from the lowest: compounds 1 and 3 (each within the scatter of the next); then compound 2.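

In this assay the change of thiomorpholin-4-yl to morpholin-4-yl on a thiocarbonyl carbon can now be read on its own, and it gives a number 17 percentage points lower from compound 2 to compound 3 (beyond the scatter) with the methyl-bearing core held constant. Methyl in place of hydrogen on an aromatic carbon can also be read alone, with morpholin-4-yl held constant, and it gives a number 3.4 percentage points higher from compound 1 to compound 3 (within the scatter) in the same read-out. Nothing shown gives a reason for the step at the thiocarbonyl carbon.

On these data alone, whether that step holds on the core of compound 1, and whether the methyl change stays as small with thiomorpholin-4-yl in place, remains open. Also open, as far as these compounds go, is how a piperidin-1-yl ring or an open-chain diethylamino group on the thiocarbonyl carbon would read.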